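Adding fluoro to a compound at the assay limit

The source may hold more compounds than are shown below. What is called first, only, known or untested is meant among the compounds shown, and "the series" means these compounds.

In an ADME assay on DU-145 cells (Homo sapiens) for cytotoxicity, read by MTT assay, with a stated time of 72 h (a lower number here means a stronger inhibitor, a higher number a weaker inhibitor), compound 1 (`COc1ccc(C2=C(c3cc(OC)c(OC)c(OC)c3)C(=O)C(OC(C)=O)C2)cc1OC(C)C`) gives > 100 ug/mL and this is a limit, not a number. Going by these compounds, compound 2 (`COc1ccc(C2=C(c3cc(OC)c(OC)c(OC)c3)C(=O)C(OC(C)=O)C2)cc1`) gives > 100 ug/mL and this too is a limit, so its true standing is unknown. Among the measured compounds shown here, the only measured step is a step that the two limits leave unreadable from compound 1 to compound 2 and it puts hydrogen in place of isopropoxy on an aromatic carbon. It therefore offers no size to carry forward. The evidence so far is the limit of > 100 ug/mL in this assay, at which 2 of the 2 values shown sit, and that is a limit only. Compound 3 (`COc1ccc(C2=C(c3cc(OC)c(OC)c(OC)c3)C(=O)C(OC(C)=O)C2)cc1F`) differs from compound 2 by fluoro in place of hydrogen on an aromatic carbon and so turns 4-methoxyphenyl into 3-fluoro-4-methoxyphenyl. The expected step in this assay is a step that the limit leaves unreadable from compound 2 to compound 3 and nothing beyond the scatter is anticipated. For compound 3 the estimate is 120 ug/mL with an expected range from 50 ug/mL to 300 ug/mL and another limit is the likeliest report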

Compound 3, half-maximal inhibitory concentration: 16 ug/mL
Estimate against measurement, compound 3: 7.5-fold (0.88 log units) above; measured number below the stated range.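

In this assay, among the compounds shown here, this position on the ring is the first place where a change gives a readable result: with the methoxy group ortho to it, fluoro in place of hydrogen gives an at least 6.2-fold lower number from compound 2 to compound 3 (0.79 log units; beyond the scatter). Set against the isopropoxy group at the same position, fluoro gives an at least 6.2-fold lower number from compound 1 to compound 3 (0.79 log units; beyond the scatter), so this position can respond to a change of one group, even one of a single heavy atom. Both sizes are minimum figures and not exact ones because the starting compounds stand at a limit: the limit of > 100 ug/mL in this assay, at which 2 of the 3 values shown sit.

Going by these compounds, what a chlorine atom, a hydroxyl group or an amine would do at this position remains open. Also open, on these data alone, are how far the true values of compound 1 and compound 2 lie from compound 3, and whether fluoro on another carbon of this ring would give a similar step.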